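The compounds below may be only part of what the source reports. "The series", "measured", "known", "first", "only" and "open" are said of these compounds alone.

Compound 1 `O=C1OC[C@H](Cc2ccccc2)[C@H]1Cc1ccc(F)cc1`: 57000 nM
Compound 2 `Clc1ccc(C[C@H]2COC[C@@H]2Cc2ccccc2)cc1Cl`: 19000 nM
Compound 3 `O=C1OC[C@H](Cc2ccccc2O)[C@H]1Cc1ccc(Cl)c(Cl)c1`: 33000 nM

In a functional assay on HL-60 cells (Homo sapiens) for cytotoxicity, read by WST assay, with a stated time of 48 h (on this read-out higher numbers stand for an effect only at larger amounts of compound and lower numbers for an effect already at smaller amounts), compound 2 gives 19000 nM. Compound 3, at 33000 nM, lies within the scatter of compound 2. Compound 1, at 57000 nM, stands at a higher number than compound 2, and that gap lies beyond the scatter.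

Compound 4 `CCOc1ccccc1C[C@H]1COC[C@@H]1Cc1ccc(Cl)c(Cl)c1` has not yet been measured. It departs from compound 2 at one place: ethoxy in place of hydrogen on an aromatic carbon. This is ethoxy in place of hydrogen on an aromatic carbon, ortho to a large group.

For the measured compounds named here, no pair of measured compounds shows what such a change does, so the expectation starts from compound 2 at 19000 nM. In this assay no step beyond the scatter is expected, with at most a slight lean toward a lower number. The estimate means a 1.3-fold lower number from compound 2 to compound 4 (0.10 log units; within the scatter), an expected change that stays within the scatter. For compound 4 the estimated value is 15000 nM, with an expected range from 6000 nM to 40000 nM.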

Compound 4, half-maximal effective concentration: 29000 nM
The estimate for compound 4 lay 1.9-fold (0.29 log units) below the measured number, and the stated range covers the measured number.
By their numbers in this assay, from the lowest: compounds 2, 4, 3 and 1 (each within the scatter of the next, the first and the last beyond it).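

In this assay, ethoxy in place of hydrogen on an aromatic carbon, ortho to a large group, gives a step of a 1.5-fold higher number from compound 2 to compound 4 (0.18 log units; within the scatter). This position therefore carries ethoxy, with its 3 heavy atoms and 1 hydrogen-bond acceptor, without a step beyond the scatter, at least on the core of compound 2. For the compounds shown here, compounds 1, 2 and 3 could not show this, as no two of them differ in only one place, so this is the first single change that can be read here.

Going by these compounds, whether the same carbon would also tolerate an amine, a carboxylic acid or a longer chain stays open, as does the effect of ethoxy on another carbon of that ring. Nothing in the available data explains the size of this step.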